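A Second Methyl on the Core of Compound 1

The compounds below may be only part of what the source reports. "The series", "measured", "known", "first", "only" and "open" are said of these compounds alone.

Compound 1, with the structure `CCOC(=O)c1sc2ccccc2c1Nc1cc(OC)c(OC)c(OC)c1`, was tested in a functional assay on SEM cells (Homo sapiens) for cytotoxicity, read by MTT assay, with a stated time of 72 h (on this read-out lower numbers stand for stronger inhibition and higher numbers for weaker inhibition), where compound 1 gives 1900 nM. A close relative, compound 2, has the structure `CCOC(=O)c1sc2cccc(C)c2c1Nc1cc(OC)c(OC)c(OC)c1` and in this assay compound 2 gives 1930 nM. Compound 1 stands at the lower of these two numbers, though the gap to compound 2 is within the scatter: a 1.0-fold higher number from compound 1 to compound 2 (0.01 log units; within the scatter), after a methyl in place of hydrogen on an aromatic carbon. Compound 3, with the structure `CCOC(=O)c1sc2cc(C)ccc2c1Nc1cc(OC)c(OC)c(OC)c1`, has not yet been measured. It differs from compound 1 in one place: methyl in place of hydrogen on an aromatic carbon. For the measured compounds named here, the only measured step resembling this change, from compound 1 to compound 2, stayed within the scatter, so no step beyond the scatter is expected in this assay here either, in either direction. Compound 3 is therefore expected to give about 1900 nM, with a likely range from 1000 nM to 3600 nM, an expected step of no change at the digits printed from compound 1 to compound 3 (within the scatter).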

Compound 3, half-maximal inhibitory concentration: 1.5 nM
Estimate against measurement, compound 3: 1300-fold (3.10 log units) above; measured number below the stated range.
By their numbers in this assay, from the lowest: compound 3; then compounds 1 and 2 (each within the scatter of the next).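

Placed on this aromatic carbon, the same swap of hydrogen for methyl gives a 1300-fold lower number from compound 1 to compound 3 (3.10 log units; beyond the scatter) in this assay while the swap in the other compound shown gives a 1.0-fold higher number from compound 1 to compound 2 (0.01 log units; within the scatter) with no real change. What matters on this core is therefore where the methyl sits and not simply that one is added: here the effect belongs to the place meta to a fused ring and para to a fused ring. Nothing in the available data explains why so small a change has so large an effect.

The compounds shown leave open whether a longer chain such as ethyl, or an amine, on the same aromatic carbon would match compound 3, which gives 1.5 nM in this cell line. They also leave open whether this sharp dependence on place holds in other cell types.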